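Benzyl in place of isopropyl: compound 3 to compound 4

The compounds below may be only part of what the source reports. "The series", "measured", "known", "first", "only" and "open" are said of these compounds alone.

Measured in an ADME assay on Vero cells (Chlorocebus sabaeus) for cytotoxicity, read by MTT assay, with a stated time of 72 h; on this read-out higher numbers stand for weaker inhibition and lower numbers for stronger inhibition:
- compound 1 `Cc1c(C(=O)OCc2ccccc2)[n+]([O-])c2cc(F)c(F)cc2[n+]1[O-]`: 55300 nM
- compound 2 `CCOC(=O)c1c(C)[n+]([O-])c2cc(-n3ccnc3)c(F)cc2[n+]1[O-]`: 129000 nM
- compound 3 `Cc1c(C(=O)OC(C)C)[n+]([O-])c2cc(F)c(-n3ccnc3)cc2[n+]1[O-]`: 113000 nM

Compound 3, at 113000 nM, lies within the scatter of compound 2 at 129000 nM. Its number is higher, beyond the scatter, than that of compound 1 at 55300 nM.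

Compound 4 `Cc1c(C(=O)OCc2ccccc2)[n+]([O-])c2cc(F)c(-n3ccnc3)cc2[n+]1[O-]` differs from compound 3 in one place: benzyl in place of isopropyl on an oxygen next to a carbonyl group. For the measured compounds named here, the only measured step at this part of the molecule is a 1.1-fold lower number from compound 2 to compound 3 (0.06 log units; within the scatter), a swap of a smaller group. Going by the values given here, no measured pair shows the benzyl change alone. Compound 1, at 55300 nM, carries the same benzyl but differs from compound 4 elsewhere too, so it offers only a weak hint towards lower numbers. A small step downwards in this assay is therefore expected, probably not clearly beyond the scatter. The expected step is a 1.4-fold lower number from compound 3 to compound 4 (0.15 log units; within the scatter). For compound 4 the estimated value is 80000 nM, with an expected range of 42000 nM to 140000 nM.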

Compound 4, half-maximal inhibitory concentration: 107000 nM
Estimate against measurement, compound 4: 1.3-fold (0.13 log units) below; low and high end bracket the measured number.
By their numbers in this assay, from the lowest: compounds 1, 4, 3 and 2 (each within the scatter of the next, the first and the last beyond it).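

In this assay, the benzyl change is now read alone at this position, and a 1.1-fold lower number from compound 3 to compound 4 (0.02 log units; within the scatter) gives no difference that stands out from the scatter; the listed step for phenyl in place of methyl on a saturated chain carbon bound to an oxygen next to a carbonyl group, a 1.2-fold lower number from compound 2 to compound 4 (0.08 log units; within the scatter), is also within it, so all steps measured at this position lie within the scatter. With benzyl held constant, 1H-imidazol-1-yl in place of fluoro on an aromatic carbon, a 1.9-fold higher number from compound 1 to compound 4 (0.29 log units; within the scatter), also stays within the scatter. No measurement at hand offers an explanation for these results.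

Going by these compounds, whether a longer chain or a carboxylic acid on this oxygen would give a step beyond the scatter remains open. Also open, on these data alone, is how an amine in place of 1H-imidazol-1-yl on the aromatic carbon would read.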